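Bromophenyl vinyl sulfone ketones: effect of an added nitro group

The source may report more compounds than this note shows. Statements on the series, on what has been measured and on what is new or still open speak of the compounds shown alone.

Measured so far:
compound 1 `O=C(/C(=C\c1ccc(Br)cc1)S(=O)(=O)c1ccc(Br)cc1)c1ccc(Br)cc1`, 10000 nM
compound 2 `Cc1ccc(S(=O)(=O)/C(=C/c2ccc(Br)cc2)C(=O)c2ccc(Br)cc2)cc1`, 10000 nM

Both measurements come from a functional assay on DU-145 cells (Homo sapiens) for inhibition, read by trypan blue exclusion, with a stated time of 96 h; on this read-out higher numbers stand for weaker inhibition of growth and lower numbers for stronger inhibition of growth. Compound 1 is level with compound 2 at the digits shown; the single step of no change at the digits printed from compound 1 to compound 2 (within the scatter) lies within the scatter, so the change of methyl in place of bromo on an aromatic carbon left growth inhibition unchanged.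

Compound 3 `O=C(/C(=C\c1ccc(Br)c([N+](=O)[O-])c1)S(=O)(=O)c1ccc(Br)cc1)c1ccc(Br)cc1` differs from compound 1 by nitro in place of hydrogen on an aromatic carbon. Going by the values given here, no measured step bears directly on the addition of a nitro group on the shared core; the only step, from compound 1 to compound 2, concerns a different position and was flat. Because no change at the digits printed from compound 1 to compound 2 (within the scatter) showed nothing beyond the scatter, a step of no size beyond the scatter is expected here as well, no change at the digits printed from compound 1 to compound 3 (within the scatter). Compound 3 is therefore estimated at 10000 nM, within a range from 4000 nM to 25000 nM.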

Compound 3, concentration for 50% growth inhibition: 10000 nM
Estimate against measurement, compound 3: no gap at the digits printed; low and high end bracket the measured number.
By their numbers in this assay, from the lowest: compounds 1, 2 and 3 (each within the scatter of the next).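

In this assay the change from 4-bromophenyl to 4-bromo-3-nitrophenyl gives no change at the digits printed from compound 1 to compound 3 (within the scatter) and so leaves growth inhibition where it stood. Going by these compounds alone, the earlier pair spoke only to methyl in place of bromo at a different position; this is the first reading on this aromatic carbon, ortho to a bromo group and meta to a large group, and here nitro in place of hydrogen produces no shift beyond the scatter. No measured data at hand offer an explanation for this flat result.

As far as these compounds go, whether an amine or a carboxylic acid on this same aromatic carbon would move growth inhibition remains open. From the compounds shown here alone, with only flat steps in hand, it is also open which change on the shared core, if any, would move it at all.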